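Chain lengthening before the isothiocyanate in two series

The source may report more compounds than this note shows. Statements on the series, on what has been measured and on what is new or still open speak of the compounds shown alone.

Compound 1 `CN(C)C(=O)c1cc2cnc(Nc3ccc(S(=O)(=O)NCCCN=C=S)cc3)nc2n1C1CCCC1` and compound 2 `CN(C)C(=O)c1cc2cnc(Nc3ccc(S(=O)(=O)NCCCCN=C=S)cc3)nc2n1C1CCCC1` share one core; compound 3 `CN(C)C(=O)c1cc2cnc(Nc3ccc(C(=O)NCCCCN=C=S)cc3)nc2n1C1CCCC1` and compound 4 `CN(C)C(=O)c1cc2cnc(Nc3ccc(C(=O)NCCCCCN=C=S)cc3)nc2n1C1CCCC1` share another. The core of compound 3 differs from that of compound 1 by a group of 10 heavy atoms (6 carbon, 2 nitrogen, 1 oxygen, 1 sulfur; no ring) in place of a group of 10 heavy atoms (4 carbon, 2 nitrogen, 2 oxygen, 2 sulfur; no ring), on an aromatic carbon. In a functional assay on NCI-H1299 cells (Homo sapiens) for inhibition, read by CCK-8 assay, with a stated time of 72 h, tested at 1 uM (a higher number here means a stronger effect of the compound at the concentration tested, a lower number a weaker effect), compound 1 gives 41.3%, compound 2 gives 29.9% and compound 3 gives 55.2%; compound 3 stands highest of the three, with a number 13.9 percentage points higher from compound 1 to compound 3 (beyond the scatter) and a number 25.3 percentage points higher from compound 2 to compound 3 (beyond the scatter).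

The change from compound 1 to compound 2 is a group of 4 heavy atoms (2 carbon, 1 nitrogen, 1 sulfur; no ring) in place of a group of 3 heavy atoms (1 carbon, 1 nitrogen, 1 sulfur; no ring), on a saturated chain carbon, three bonds along the chain from a sulfonamide nitrogen; it gave a number 11.4 percentage points lower from compound 1 to compound 2 (beyond the scatter). Compound 4 is reached from compound 3 by a group of 4 heavy atoms (2 carbon, 1 nitrogen, 1 sulfur; no ring) in place of a group of 3 heavy atoms (1 carbon, 1 nitrogen, 1 sulfur; no ring), on a saturated chain carbon, four bonds along the chain from an amide-type nitrogen. This is the same kind of change, not the same one: the place differs, three bonds along the chain from a sulfonamide nitrogen in the first pair against four bonds along the chain from an amide-type nitrogen in the second. Going by the values given here, only the one measured pair speaks to this change, so the expectation rests on it alone. Because of a number 11.4 percentage points lower from compound 1 to compound 2 (beyond the scatter) a drop of similar size is expected for compound 4, estimated as a number 10.2 percentage points lower from compound 3 to compound 4 (beyond the scatter). Compound 4 is expected at 45%, within 30% to 60%.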

Compound 4, a percentage reported as inhibition, at one concentration (the size of the read-out at that concentration, not a potency): 50.3%
Beside the measured number, compound 4's estimate is 5.3 percentage points below it; measured number inside the range.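

In this assay the same chain change was read on two cores, and the two steps cannot be told apart: the same change on two cores in this assay, a number 11.4 percentage points lower (beyond the scatter) from compound 1 to compound 2 and a number 4.9 percentage points lower (within the scatter) from compound 3 to compound 4, 6.5 percentage points apart, within the scatter of two such steps. The step on the second core, a number 4.9 percentage points lower from compound 3 to compound 4 (within the scatter), is consistent with the change carrying over, but a single pair on each core does not show that it carries over with a fixed size, nor that it lowers the number at all on the core of compound 3. Between the cores, the steps read a number 20.4 percentage points higher from compound 2 to compound 4 (beyond the scatter) and a number 9 percentage points higher from compound 1 to compound 4 (within the scatter), so compound 4 separates from compound 2 but not from compound 1.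

Still open, from the compounds shown here alone, is how a longer chain would read on either core, and whether an amine in place of the isothiocyanate would keep the inhibition. A read-out at one concentration also shows only a stronger or weaker effect at that concentration and leaves open how these compounds would read at any other.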